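The source may hold more compounds than are shown below. What is called first, only, known or untested is meant among the compounds shown, and "the series" means these compounds.

In a functional assay on CHO cells for agonist activity at Free fatty acid receptor 1 (Homo sapiens), read by FLIPR, tested at 100 nM (on this read-out lower numbers stand for a weaker effect and higher numbers for a stronger effect at the one concentration tested), the three measured compounds stand as follows:
compound 1 `O=C(O)COc1ccc(NC(=O)c2ccccc2)cc1F` gives 3.56%;
compound 2 `O=C(O)COc1ccc(NC(=O)COc2ccccc2)cc1F` gives 29.8%;
compound 3 `CC(Oc1ccccc1)C(=O)Nc1ccc(OCC(=O)O)c(F)c1` gives 35.7%.

Compound 2 is second highest of the three in this assay, close to compound 3 and well above compound 1, that gap lying beyond the scatter. Compound 4 `Cc1ccccc1OCC(=O)Nc1ccc(OCC(=O)O)c(F)c1` differs from compound 2 by methyl in place of hydrogen on an aromatic carbon. Within the data shown here, the only measured step that bears on it is a number 5.9 percentage points higher from compound 2 to compound 3 (within the scatter), in which a methyl entered a saturated chain carbon instead of the ring; it moved the number only within the scatter. Among the measured compounds shown here, no measured step puts a methyl on the aromatic ring, so the guidance is indirect. Compound 4 is therefore expected to give about 32%, in the range 15% to 55%. The expected step is a number 2.2 percentage points higher from compound 2 to compound 4 (within the scatter), nothing beyond the scatter.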

Compound 4, a percentage reported as activity, at one concentration (the size of the read-out at that concentration, not a potency): 20.8%
Compound 4: middle estimate off by 11.2 percentage points, on the high side; the measured number falls inside the stated range.
By their numbers in this assay, from the lowest: compound 1; then compounds 4, 2 and 3 (each within the scatter of the next, the first and the last beyond it).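

Among these compounds, this is the first look at the aromatic ring of the phenoxy group: putting a methyl there, ortho to a large group, gives a number 9 percentage points lower from compound 2 to compound 4 (within the scatter) in this assay, so this ring carbon carries the methyl without a change beyond the scatter. The methyl on the saturated chain gave a number 5.9 percentage points higher from compound 2 to compound 3 (within the scatter) in the same way. No measurement here explains the size of either step. Still open, on these data alone, is how a methoxy group or a chlorine atom would read on this ring carbon, and how a methyl would read on the other ring carbons.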